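The source may report more compounds than this note shows. Statements on the series, on what has been measured and on what is new or still open speak of the compounds shown alone.

Measured so far in an ADME assay on PBMC cells (Homo sapiens) for cytotoxicity; on this read-out higher numbers stand for lower toxicity in this test and lower numbers for higher toxicity in this test:
- Compound 1 `CC(CCNC(=O)c1c(Cl)cncc1Cl)N1CCC(C(Oc2ccccn2)c2ccc(C(F)(F)F)cc2)CC1`: 34100 nM
- Compound 2 `COC(=O)c1cccc(OC(c2ccc(C(F)(F)F)cc2)C2CCN(C(C)CCNC(=O)c3c(Cl)cncc3Cl)CC2)c1`: 15200 nM
- Compound 3 `CC(CCNC(=O)c1c(Cl)cncc1Cl)N1CCC(C(Oc2cccc(C(F)(F)F)c2)c2ccc(C(F)(F)F)cc2)CC1`: 7000 nM

Compound 3 has the lowest number of the three, and its steps to both others lie beyond the scatter. Compound 4 `CC(CCNC(=O)c1c(Cl)cncc1Cl)N1CCC(C(Oc2ccccc2C(F)(F)F)c2ccc(C(F)(F)F)cc2)CC1` contains the same atoms as compound 3, joined differently: 2-(trifluoromethyl)phenyl in place of 3-(trifluoromethyl)phenyl on an oxygen on a saturated carbon. Here 2-(trifluoromethyl)phenyl stands in place of 3-(trifluoromethyl)phenyl on an oxygen on a saturated carbon, so the group stays the same and only its place on the ring changes.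

Going by the values given here, three measured steps concern this same oxygen substituent: a 2.2-fold lower number from compound 1 to compound 2 (0.35 log units; beyond the scatter), a 4.9-fold lower number from compound 1 to compound 3 (0.69 log units; beyond the scatter) and a 2.2-fold lower number from compound 2 to compound 3 (0.34 log units; beyond the scatter). All three are modest, and each replaces one group with a different one. None of them shows a trifluoromethyl group changing place on the ring, so they offer only a rough guide. The closest evidence is the value of compound 3, 7000 nM, which serves as the starting point. A small step is expected, probably not beyond the scatter, and its direction is uncertain. The expected step is a 1.1-fold higher number from compound 3 to compound 4 (0.06 log units; within the scatter). For compound 4 the estimated value is 8000 nM, with an expected range from 3500 nM to 18000 nM.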

Compound 4, half-maximal cytotoxic concentration: 12500 nM
Compound 4: the middle estimate sits 1.6-fold (0.19 log units) below what was measured, within the range that was stated.
By their numbers in this assay, from the lowest: compounds 3, 4 and 2 (each within the scatter of the next, the first and the last beyond it); then compound 1.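

In this assay, moving the trifluoromethyl group to another place on the ring gives a 1.8-fold higher number from compound 3 to compound 4 (0.25 log units; within the scatter) and so stays inside the normal variation of repeated tests; this pair, the first to keep the group and change only its place, shows no clear effect of that place. Compound 4 also cannot be told apart from the ester-bearing compound, with a 1.2-fold lower number from compound 2 to compound 4 (0.08 log units; within the scatter) for the change from 3-(methoxycarbonyl)phenyl to 2-(trifluoromethyl)phenyl, even though compound 2 and compound 3 do differ clearly from each other. The new compound also extends the earlier picture: with a 2.7-fold lower number from compound 1 to compound 4 (0.44 log units; beyond the scatter) beyond the scatter, all three substituted phenyl compounds shown give lower numbers than the pyridin-2-yl compound, and none of the compounds goes against this.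

No measurement shown here explains these differences.

From the compounds shown here alone, it remains open whether a plain phenyl group on this oxygen, or a phenyl ring carrying an amine or a carboxylic acid, would give a number closer to compound 1 or to compound 3.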